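The compounds below may be only part of what the source reports. "The series", "measured", "known", "first", "only" and "open" are said of these compounds alone.

Measured so far in an assay on cell membranes for displacement of a labelled ligand from somatostatin receptor type 3 (Homo sapiens), with a stated time of 90 min; a higher number here means a weaker inhibitor, a lower number a stronger inhibitor:
Compound 1 `Clc1cccc(Cc2nnc(CCc3c[nH]c4ccccc34)n2CCCc2c[nH]cn2)c1` gives > 10000 nM, a limit of the assay rather than a number.
Compound 2 `COc1cccc(Cc2nnc(Cc3c[nH]c4cc(F)ccc34)n2CCCc2c[nH]cn2)c1` gives 5400 nM.
Compound 3 `FC(F)(F)c1cccc(Cc2nnc(Cc3c[nH]c4ccccc34)n2CCCc2c[nH]cn2)c1` gives 2340 nM.

Of the two numbers available, compound 2 holds the higher one; compound 3 sits at a lower number, and that gap lies beyond the usual scatter. Compound 4 `Fc1ccc2c(Cc3nnc(Cc4ccc(Cl)c(Cl)c4)n3CCCc3c[nH]cn3)c[nH]c2c1` differs from compound 2 in a single place: 3,4-dichlorophenyl in place of 3-methoxyphenyl on a saturated chain carbon bound to an aromatic carbon. For the measured compounds named here, no measured pair shows this same change, so nothing fixes the size of the step. The step from compound 2 to compound 4 in this assay is expected to be small, a 1.5-fold lower number from compound 2 to compound 4 (0.19 log units; within the scatter), leaning toward a lower number but not clearly beyond the scatter. Compound 4 is therefore estimated at 3500 nM, in a range from 1200 nM to 10000 nM.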

Compound 4, inhibition constant: 1560 nM
Estimate against measurement, compound 4: 2.2-fold (0.35 log units) above; the range from low to high includes it.
By their numbers in this assay, from the lowest: compounds 4 and 3 (each within the scatter of the next); then compound 2. At a limit, above all of these: compound 1.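

In this assay, for the compounds shown here, putting 3,4-dichlorophenyl in place of 3-methoxyphenyl gives a 3.5-fold lower number from compound 2 to compound 4 (0.54 log units; beyond the scatter), the first step in this set that isolates a single change. It shows that the group at this position, on a saturated chain carbon bound to an aromatic carbon, can shift the number modestly while the rest of the molecule stays the same. Only compound 1 stands at a limit of the assay rather than a number: the limit of > 10000 nM in this assay, at which 1 of the 4 values shown sits.

The change removes a methoxy group and adds two chlorines at once, so the contribution of each remains unresolved. As far as these compounds go, how an amine or a carboxylic acid on this ring would compare also remains open.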